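Chloro to methoxy step in the paw edema series

This account rests on a few compounds, and the source may have more. Where it says the series, first, only, none or still open, it means among the compounds named here.

In a functional assay on the whole organism (strain albino) for inhibition, with Rattus norvegicus as the target, read by paw edema, with stated times of 30 min and 4 h, at a dose of 100 mg/kg by the oral route (a higher number here means more inhibition at the dose given (going by the name of the read-out), a lower number less inhibition), the measured compounds stand as follows:

compound 1, `CC(O[N+](=O)[O-])C(=O)Nc1ccc(C(=O)/C=C/c2ccc(Cl)cc2)cc1`: 61%
compound 2, `COc1ccc(/C=C/C(=O)c2ccc(NC(=O)C(C)O[N+](=O)[O-])cc2)cc1`: 43%
compound 3, `O=C(COCc1c(-c2ccccc2)no[n+]1[O-])Nc1ccc(C(=O)/C=C/c2ccc(Cl)cc2)cc1`: 75%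

Compound 3 gives the highest number of the three; its margins over compound 1 and compound 2 are both beyond the scatter. The difference between the core of compound 3 and the core of compound 1 is not broken down here.

One change is measured within the set: methoxy in place of chloro on an aromatic carbon. In this assay it made a step of a number 18 percentage points lower from compound 1 to compound 2 (beyond the scatter).

Compound 4, `COc1ccc(/C=C/C(=O)c2ccc(NC(=O)COCc3c(-c4ccccc4)no[n+]3[O-])cc2)cc1`, is unmeasured. It differs from compound 3 by methoxy in place of chloro on an aromatic carbon, the same change as from compound 1 to compound 2, at a place described in the same words.

Among the measured compounds shown here, because only the single step of a number 18 percentage points lower from compound 1 to compound 2 (beyond the scatter) is available, the step from compound 3 to compound 4 is expected to be of similar size, a number 18 percentage points lower from compound 3 to compound 4 (beyond the scatter), with wider uncertainty since it is a second occurrence on a different core. Compound 4 is therefore estimated at 57%, between 44% and 70%.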

Compound 4, a percentage reported as inhibition, in the whole organism at one dose (the size of the read-out at that dose, not a potency): 55%
The estimate for compound 4 lay 2 percentage points above the measured number; the measured number falls inside the stated range.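

In this assay, methoxy in place of chloro on an aromatic carbon gave a number 20 percentage points lower from compound 3 to compound 4 (beyond the scatter), so the change carried over from one core to the other with a step of much the same size: the same change on two cores in this assay, a number 18 percentage points lower (beyond the scatter) from compound 1 to compound 2 and a number 20 percentage points lower (beyond the scatter) from compound 3 to compound 4, 2 percentage points apart, within the scatter of two such steps. This rests on two cores and one pair of groups, so it shows that the step repeated here, not that it would repeat on any further core. The read-out gives the size of the effect at a single oral dose and is not a potency, so the two pairs say nothing about how chloro and methoxy compare at other doses, and nothing about where the step comes from.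

The compounds shown leave open whether other groups at the same place, such as fluoro, a hydroxyl or an amine, would stand nearer to chloro or to methoxy. They also leave open whether the step holds on a core with a longer chain in place of those in compound 1 and compound 3.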